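Swapping methoxy for methyl on a hydroxypropyl amide

The source may hold more compounds than are shown below. What is called first, only, known or untested is meant among the compounds shown, and "the series" means these compounds.

Compound 1 `COc1ccc(C(=O)CCC(=O)NCCCO)cc1` was tested in a functional assay on the whole organism (Central nervous system) with Mus musculus as the target (on this read-out lower numbers stand for an effect already at smaller amounts and higher numbers for an effect only at larger amounts of compound), where it gives 800 mg/kg. That is the highest of the two numbers recorded; compound 2 `O=C1CCC2(c3ccc(Cl)cc3)OCCCN12` gives 81.2 mg/kg, a gap that lies beyond the usual scatter. Compound 3 `Cc1ccc(C(=O)CCC(=O)NCCCO)cc1` has not been measured. It differs from compound 1 in one place: methyl in place of methoxy on an aromatic carbon. For the measured compounds named here, no measured pair shows what such a swap does here. The step of a 1.1-fold lower number from compound 1 to compound 3 (0.06 log units; within the scatter) is expected to be small, with no direction beyond the scatter. Compound 3 is therefore estimated at 700 mg/kg, with a range from 350 mg/kg to 1500 mg/kg.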

Compound 3, dose for half-maximal effect: 700 mg/kg
Estimate against measurement, compound 3: no gap at the digits printed; the range from low to high includes it.
By their numbers in this assay, from the lowest: compound 2; then compounds 3 and 1 (each within the scatter of the next).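

In this assay methyl in place of methoxy on an aromatic carbon para to a large group gives a 1.1-fold lower number from compound 1 to compound 3 (0.06 log units; within the scatter) and so stays within the scatter. This single pair shows that, on this core, the oxygen of the methoxy group can go without a measurable change in the read-out. No supporting data explain this result.

From the compounds shown here alone, it remains open whether an amine or a carboxylic acid on this aromatic carbon would give a step beyond the scatter. A longer chain in place of the hydroxypropyl group is also untested among the compounds shown.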